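A few compounds are considered here, and "the series" means these few. Any claim that something is new, unique, unknown or untested is made for them only; others in the source may bear on it.

Compound 2 `Cc1ccccc1-c1nc(CN2CCC(C(=O)NCCCN3CCC(C)(C)CC3)CC2)c(C)o1` is the point from which the other compounds are read. In an ADME assay on Huh7.5.1 cells (Homo sapiens) for cytotoxicity, read by ATP content, with a stated time of 48 h (a higher number here means that more compound is tolerated, a lower number that less compound is tolerated), compound 2 gives 10200 nM. Compound 1 `Cc1ccccc1-c1nc(CN2CCC(C(=O)NCCCN3CCC(C(C)C)CC3)CC2)c(C)o1` differs from it in one place, by 4-isopropylpiperidin-1-yl in place of 4,4-dimethylpiperidin-1-yl on a saturated chain carbon, three bonds along the chain from an amide-type nitrogen, and in this assay compound 1 gives 4280 nM, so that a 2.4-fold lower number from compound 2 to compound 1 (0.38 log units; beyond the scatter). Compound 3 `Cc1cccc(Cl)c1-c1nc(CN2CCC(C(=O)NCCCN3CCC(C)(C)CC3)CC2)c(C)o1` differs from compound 2 in a different place, by chloro in place of hydrogen on an aromatic carbon; in this assay compound 3 gives 11700 nM, which makes a 1.1-fold higher number from compound 2 to compound 3 (0.06 log units; within the scatter). Compound 3 thus stands with compound 2 in this assay, while compound 1 sits apart from both.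

Compound 4 `Cc1cccc(Cl)c1-c1nc(CN2CCC(C(=O)NCCCN3CCC(C(C)C)CC3)CC2)c(C)o1` has not yet been measured in this assay. It stands to compound 3 as compound 1 stands to compound 2: the change is 4-isopropylpiperidin-1-yl in place of 4,4-dimethylpiperidin-1-yl on a saturated chain carbon, three bonds along the chain from an amide-type nitrogen, and the place is described in exactly the same words for both pairs, so this is the same change made on a different core. The two cores differ by chloro in place of hydrogen on an aromatic carbon, a change that in this assay produced a 1.1-fold higher number from compound 2 to compound 3 (0.06 log units; within the scatter).

Because a 2.4-fold lower number from compound 2 to compound 1 (0.38 log units; beyond the scatter), the same change on the core of compound 3 is expected to give a step of about the same size, and the step from compound 3 to compound 4 is estimated as a 2.4-fold lower number from compound 3 to compound 4 (0.38 log units; beyond the scatter). Compound 4 is therefore expected to give roughly 4900 nM in this assay, with the likely range estimated from 2400 nM to 10000 nM. This expectation rests on a single measured instance of the change and on the cores differing only by chloro in place of hydrogen on an aromatic carbon.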

Compound 4, half-maximal cytotoxic concentration in the Huh7.5.1 assay: 4910 nM
Compound 4: middle estimate off by 1.0-fold (0.00 log units), on the low side, within the range that was stated.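

In the Huh7.5.1 assay, 4-isopropylpiperidin-1-yl in place of 4,4-dimethylpiperidin-1-yl gives a 2.4-fold lower number from compound 3 to compound 4 (0.38 log units; beyond the scatter), and the change carries over to the chlorinated core with its size intact: the same change on two cores in the Huh7.5.1 assay, a 2.4-fold lower number (0.38 log units; beyond the scatter) from compound 2 to compound 1 and a 2.4-fold lower number (0.38 log units; beyond the scatter) from compound 3 to compound 4, 1.0-fold (0.00 log units) apart, within the scatter of two such steps The chloro change, read on the other pair, gives a 1.1-fold higher number from compound 1 to compound 4 (0.06 log units; within the scatter), so that it stays within the scatter on both piperidine partners and the two changes behave here as independent of one another: the same change on two cores in the Huh7.5.1 assay, a 1.1-fold higher number (0.06 log units; within the scatter) from compound 2 to compound 3 and a 1.1-fold higher number (0.06 log units; within the scatter) from compound 1 to compound 4, 1.0-fold (0.00 log units) apart, within the scatter of two such steps This is one square of four compounds in one cell assay, on cores that differ only by chloro in place of hydrogen on an aromatic carbon, so it does not show that the step would hold on cores that differ more widely, or that it would hold in a physicochemical assay for solubility, in phosphate buffer, measured as kinetic solubility, at pH 7.4; a lower number here means a less soluble compound, a higher number a more soluble compound.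

In the physicochemical assay compound 3 gives > 74 ug/mL, which is a limit of the assay and not a number. In the physicochemical assay compound 4 gives > 76 ug/mL, which is also a limit of the assay and not a number. The step between these two compounds cannot be read. The compounds shown also leave open whether the same step would appear with fluoro or methoxy in place of chloro, with a chain longer than propyl, or with a morpholine in place of the piperidine.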